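Triazole-linked cinnamic acids: hydroxymethyl for methoxy on the aryl ring

This account rests on a few compounds, and the source may have more. Where it says the series, first, only, none or still open, it means among the compounds named here.

Compound 3 `COc1ccc(-n2cc(COc3c(/C=C\C(=O)O)ccc(OC)c3CC=C(C)C)nn2)cc1` has no number in a functional assay on PC-3 cells (Homo sapiens) for cytotoxicity, read by MTT assay, with a stated time of 24 h; on this read-out lower numbers stand for stronger inhibition and higher numbers for weaker inhibition; its reading stands as "not determined" (no result reported), and compound 1 `COc1ccc(/C=C\C(=O)O)c(OCc2cn(-c3ccc(NC(C)=O)cc3)nn2)c1CC=C(C)C` likewise carries "not determined" (no result reported) there, so compound 3 cannot be placed against anything measured. The one figure in the set comes from compound 2 `COc1ccc(/C=C\C(=O)O)c(OCc2cn(-c3ccccc3F)nn2)c1CC=C(C)C`, which gives 24200 nM in this assay. Compound 4 `COc1ccc(/C=C\C(=O)O)c(OCc2cn(-c3ccc(CO)cc3)nn2)c1CC=C(C)C` differs from compound 3 by hydroxymethyl in place of methoxy on an aromatic carbon. Going by the values given here, with no step between measured compounds available, the expected effect of this change is a shift of no more than the usual scatter, in no settled direction. On that basis compound 4 is expected to give about 25000 nM in this assay, within a range of 8000 nM to 80000 nM.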

Compound 4, half-maximal inhibitory concentration: 28300 nM
The estimate for compound 4 lay 1.1-fold (0.05 log units) below the measured number, and the stated range covers the measured number.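

In this assay, the aryl group on the aromatic nitrogen now has a second reading: 4-(hydroxymethyl)phenyl in place of 2-fluorophenyl gives a 1.2-fold higher number from compound 2 to compound 4 (0.07 log units; within the scatter), so these two groups are not separated at this position. Steps involving compound 1 or compound 3, including the methoxy to hydroxymethyl change, cannot be read, as neither compound has a number. No supporting data bear on this result.

Open, on these data alone, is how an amine or a longer chain in place of hydroxymethyl on that ring would read. Also open, as far as these compounds go, is whether any group at this position moves the number beyond the scatter.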